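Three limits on the benzyl side chain, a fourth variant

The compounds below may be only part of what the source reports. "The series", "measured", "known", "first", "only" and "open" are said of these compounds alone.

Measured in an ADME assay on isolated protein for inhibition of Dipeptidyl peptidase 9 (Homo sapiens), with stated times of 15 min, 60 s and 20 min; a higher number here means a weaker inhibitor, a lower number a stronger inhibitor:
compound 1 `CC#CCn1c(N2CCC[C@@H](N)C2)nc2c1c(=O)n(Cc1cc(C#N)ccc1C(=O)O)c(=O)n2C`: > 100000 nM
compound 2 `CC#CCn1c(N2CCC[C@@H](N)C2)nc2c1c(=O)n(Cc1cccc(F)c1C(=O)O)c(=O)n2C`: > 100000 nM
compound 3 `CC#CCn1c(N2CCC[C@@H](N)C2)nc2c1c(=O)n(Cc1ccc(Br)cc1C(=O)OCC)c(=O)n2C`: > 100000 nM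

Compound 1 stands at the boundary of this assay, and its value is a limit, not a number. Compound 2 also gives only a limit. Compound 3 gives only a limit as well. The steps a step that the two limits leave unreadable from compound 1 to compound 2, a step that the two limits leave unreadable from compound 1 to compound 3 and a step that the two limits leave unreadable from compound 2 to compound 3 therefore cannot be read, since every value sits where (the limit of > 100000 nM in this assay, at which 3 of the 3 values shown sit). Compound 4 `CC#CCn1c(N2CCC[C@@H](N)C2)nc2c1c(=O)n(Cc1c(Cl)cccc1C(=O)O)c(=O)n2C` carries 2-carboxy-6-chlorophenyl in place of 2-carboxy-5-cyanophenyl on a saturated chain carbon bound to an aromatic nitrogen. All three measured steps alter the same benzyl substituent, yet none yields a readable size, so no direction can be drawn from them. Compound 4 is therefore expected to return a limit again, the expected step of a number no higher from compound 1 to compound 4 (the limit leaves the size open) being none beyond the scatter. The estimate for compound 4 is 100000 nM, between 50000 nM and 300000 nM.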

Compound 4, half-maximal inhibitory concentration: > 100000 nM
Compound 4 ended at the assay's limit; the forecaster's own chance of this, stated with the estimate: 85%; the middle value sits exactly at the limit.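

Compound 4 gives > 100000 nM, a limit and not a number. No step linking compound 4 with compound 1, compound 2 or compound 3 can be read, since all four share that limit: the limit of > 100000 nM in this assay, at which 4 of the 4 values shown sit.

As far as these compounds go, whether these four side chains differ at all in inhibitory strength stays open.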